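Cytotoxicity limits across a fluoro-for-trifluoromethoxy pair

The source may report more compounds than this note shows. Statements on the series, on what has been measured and on what is new or still open speak of the compounds shown alone.

Compound 1 `CCOC(=O)c1c(-c2cccc(OC(F)(F)F)c2)[nH]c2cc(OC)ccc2c1=O` anchors the set. In an ADME assay on HepG2 cells (Homo sapiens) for cytotoxicity, read by luminescence, with a stated time of 72 h (a lower number here means that less compound is needed, a higher number that more compound is needed for the effect), compound 1 gives only a limit, > 21500 nM. Compound 2 `CCOC(=O)c1c(-c2cccc(F)c2)[nH]c2cc(OC)ccc2c1=O` differs from it by fluoro in place of trifluoromethoxy on an aromatic carbon. In this assay compound 2 also reaches only a limit, > 21500 nM. Compound 3 `CCOC(=O)c1c(-c2cccc(OC(F)(F)F)c2)[nH]c2cc(OC)c(F)cc2c1=O` carries a core set apart from that of compound 1 by fluoro in place of hydrogen on an aromatic carbon. In this assay compound 3 likewise stops at a limit, > 21500 nM. The steps a step that the two limits leave unreadable from compound 1 to compound 2 and a step that the two limits leave unreadable from compound 1 to compound 3 cannot be sized, since every value sits at the limit of > 21500 nM in this assay, at which 3 of the 3 values shown sit. Compound 4 `CCOC(=O)c1c(-c2cccc(F)c2)[nH]c2cc(OC)c(F)cc2c1=O` is unmeasured; it differs from compound 3 by fluoro in place of trifluoromethoxy on an aromatic carbon, the same change as from compound 1 to compound 2. The step that the limit leaves unreadable from compound 3 to compound 4 is expected to stay unreadable, resting on compound 1 and compound 2 both at the limit of > 21500 nM in this assay, at which 3 of the 3 values shown sit. Compound 4 is expected to give 30000 nM in this assay, most likely as a limit again.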

Compound 4, half-maximal effective concentration: > 21500 nM
Compound 4: no number, only a limit (the forecaster's own chance of this, stated with the estimate: 90%); the middle value is on the limit's open side.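

Neither the step from compound 3 to compound 4 nor the step from compound 2 to compound 4 can be read, since all four compounds stop at one limit: the limit of > 21500 nM in this assay, at which 4 of the 4 values shown sit.

The compounds shown leave open whether either fluoro change alters cytotoxicity at all.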